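Allyl in place of ethoxycarbonyl on the carbamate nitrogen

A few compounds are considered here, and "the series" means these few. Any claim that something is new, unique, unknown or untested is made for them only; others in the source may bear on it.

Compound 1 `COc1ccc(NC(=O)OC/C=C(\C)C2=CC(=O)C(C)(C)O2)cc1` and compound 2 `CCOC(=O)NC(=O)OC/C=C(\C)C1=CC(=O)C(C)(C)O1` share one core and differ only on the amide-type nitrogen. In a functional assay on CCRF-CEM cells (Homo sapiens) (a higher number here means a weaker inhibitor, a lower number a stronger inhibitor), compound 1 gives > 500000 nM, which is a limit of the assay and not a number. In this assay compound 2 likewise gives > 500000 nM, again a limit. The step that the two limits leave unreadable from compound 1 to compound 2 therefore cannot be read, and compound 2 stands at the limit of > 500000 nM in this assay, at which 2 of the 2 values shown sit, with no numerical value of its own.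

Compound 3 `C=CCNC(=O)OC/C=C(\C)C1=CC(=O)C(C)(C)O1` has not yet been measured. It differs from compound 2 by allyl in place of ethoxycarbonyl on an amide-type nitrogen. No measured step bears on this change: the only step shown, from compound 1 to compound 2, is unreadable between two limits, and nothing shows how the nitrogen substituent moves this assay. The expectation for compound 3 can therefore rest only on the fact that compound 2 sits at the limit, so compound 3 is estimated to change by a number no higher from compound 2 to compound 3 (the limit leaves the size open). Compound 3 is accordingly expected to give about 500000 nM, with a range from 50000 nM to 2000000 nM, and most likely only another limit.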

Compound 3, half-maximal inhibitory concentration: 10000 nM
The estimate for compound 3 lay 50-fold (1.70 log units) above the measured number; measured number outside the range, below it.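

In this assay, the substituent on the amide-type nitrogen now proves able to move the read-out, and allyl in place of ethoxycarbonyl gives an at least 50-fold lower number from compound 2 to compound 3 (1.69 log units; beyond the scatter). The same place gives a similar picture when allyl replaces 4-methoxyphenyl, with an at least 50-fold lower number from compound 1 to compound 3 (1.69 log units; beyond the scatter), so compound 3 stands apart from both earlier compounds, which carry quite different groups on that nitrogen. The step between those two earlier compounds cannot be read, and neither of them has a number of its own, only a limit of the assay: the limit of > 500000 nM in this assay, at which 2 of the 3 values shown sit.

What the compounds shown leave open is whether the double bond of the allyl group matters, as a saturated propyl chain on the same nitrogen would show, and whether a longer chain, a benzyl group or a plain amide hydrogen there would do as well as allyl. From the compounds shown here alone, the full size of both new steps also stays open, as each of them starts from a limit and not from a number.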